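Chloro for methoxy on the benzoyl ring of compound 2

The source may report more compounds than this note shows. Statements on the series, on what has been measured and on what is new or still open speak of the compounds shown alone.

Measured so far:
compound 1 `COc1cc(-c2nnc3n2NC(c2cccs2)C(C(=O)c2ccc(C)cc2)S3)cc(OC)c1OC` — 3700 nM
compound 2 `COc1ccc(C(=O)C2Sc3nnc(-c4cc(OC)c(OC)c(OC)c4)n3NC2c2cccs2)cc1` — 68000 nM

Compound 2 stands highest of the two numbers in a functional assay on HepG2 cells (Homo sapiens) for cytotoxicity, read by MTT assay, with a stated time of 48 h; a higher number here means a weaker inhibitor, a lower number a stronger inhibitor; its nearest neighbour is compound 1, which gives 3700 nM in this assay. Among the compounds with values here, the one measured step, an 18-fold higher number from compound 1 to compound 2 (1.26 log units; beyond the scatter), is the only information on the ring that carries the carbonyl. Compound 3 `COc1cc(-c2nnc3n2NC(c2cccs2)C(C(=O)c2ccc(Cl)cc2)S3)cc(OC)c1OC` differs from compound 2 by chloro in place of methoxy on an aromatic carbon. That change undoes the methoxy whose entry marked the large step from compound 1 to compound 2, but chloro is not methyl, so the return is uncertain in size. A step downward, beyond the scatter but short of the full distance back to compound 1, is expected. The estimate for compound 3 is therefore 9000 nM, with a range from 2000 nM to 40000 nM. That estimate corresponds to an expected step of a 7.6-fold lower number from compound 2 to compound 3 (0.88 log units; beyond the scatter).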

Compound 3, half-maximal inhibitory concentration: 13200 nM
The estimate for compound 3 lay 1.5-fold (0.17 log units) below the measured number, and the stated range covers the measured number.
By their numbers in this assay, from the lowest: compound 1; then compound 3; then compound 2.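

Chloro in place of methoxy, para to a large group, gives a 5.2-fold lower number from compound 2 to compound 3 (0.71 log units; beyond the scatter) in this assay, so the high number of compound 2 does not extend to every group placed there. The return is only partial: a 3.6-fold higher number from compound 1 to compound 3 (0.55 log units; beyond the scatter) shows that chloro and methyl also differ at this place, and the position therefore separates all three groups tested, with methyl lowest, chloro in the middle and methoxy highest. Nothing available accounts for this order.

Three groups at one place on one core leave open where a bare hydrogen, a fluoro, an amine or a carboxylic acid would fall in this order. Going by these compounds, whether the same order would hold on a different core also remains unknown.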